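This account rests on a few compounds, and the source may have more. Where it says the series, first, only, none or still open, it means among the compounds named here.

Compound 3 `Cc1cccc2sc(NC(=O)CCN3CCN(CCCN(C)C)CC3)nc12` gives the lowest number of the three in an assay on membranes from brain for displacement of a labelled ligand from Sigma non-opioid intracellular receptor 1 (Cavia porcellus), read by scintillation counting, with a stated time of 120 min (a higher number here means a weaker inhibitor, a lower number a stronger inhibitor), at 570 nM. Compound 2 `Cc1cccc2sc(NC(=O)CCN3CCN(CCN(C)C)CC3)nc12` gives 1000 nM there, and compound 1 `Cc1cccc2sc(NC(=O)CCN3CCN(C(C)C)CC3)nc12` gives 1300 nM. Of the measured steps, a 2.3-fold lower number from compound 1 to compound 3 (0.36 log units; beyond the scatter) was modest, while a 1.3-fold lower number from compound 1 to compound 2 (0.11 log units; within the scatter) and a 1.8-fold lower number from compound 2 to compound 3 (0.24 log units; within the scatter) both stayed within the scatter. Compound 4 `Cc1cccc2sc(NC(=O)CCN3CCN(CC4CCCCC4)CC3)nc12` differs from compound 3 by cyclohexyl in place of 2-(dimethylamino)ethyl on a saturated chain carbon bound to an amine nitrogen in a ring. The change drops the dimethylamino group shared by compounds 2 and 3 and leaves a substituent of carbon only, as in compound 1, though a larger one. The step that bears on such a loss, read in reverse, is a 2.3-fold lower number from compound 1 to compound 3 (0.36 log units; beyond the scatter); a small rise in number, near the edge of the scatter, is therefore expected. Compound 4 is estimated at 900 nM, range 300 nM to 2700 nM, which is the expected step of a 1.6-fold higher number from compound 3 to compound 4 (0.20 log units; within the scatter).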

Compound 4, inhibition constant: 35 nM
The estimate for compound 4 lay 26-fold (1.41 log units) above the measured number; the measured number lies below the stated range.
By their numbers in this assay, from the lowest: compound 4; then compounds 3, 2 and 1 (each within the scatter of the next, the first and the last beyond it).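

At the amine nitrogen in the ring, removing the dimethylamino group carries no penalty: cyclohexyl in its place gives a 16-fold lower number from compound 3 to compound 4 (1.21 log units; beyond the scatter) and a 29-fold lower number from compound 2 to compound 4 (1.46 log units; beyond the scatter) in this assay. Among the substituents of carbon only, cyclohexylmethyl in place of isopropyl gives a 37-fold lower number from compound 1 to compound 4 (1.57 log units; beyond the scatter), so carbon-only character alone does not set the number at this position. No measurement at hand accounts for these gains. Going by these compounds, whether the ring itself matters remains open, and a straight hexyl chain or a benzyl group on the same nitrogen would test that.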